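Benzoxazolone anilides at the glutamate receptor: meta-substituent swap

This account rests on a few compounds, and the source may have more. Where it says the series, first, only, none or still open, it means among the compounds named here.

Going by the values given here, compound 2, `Cc1cccc(NC(=O)c2cccc3oc(=O)[nH]c23)c1`, gives 109 nM in an assay on isolated protein for binding affinity to metabotropic glutamate receptor 5 (Homo sapiens) (a higher number here means a weaker inhibitor, a lower number a stronger inhibitor), the higher of the two numbers so far; compound 1, `O=C(Nc1cccc(Cl)c1)c1cccc2oc(=O)[nH]c12`, gives 68 nM in this assay, and the step from compound 1 to compound 2 is a 1.6-fold higher number from compound 1 to compound 2 (0.20 log units; within the scatter). Compound 3, `COc1cccc(NC(=O)c2cccc3oc(=O)[nH]c23)c1`, differs from compound 2 by methoxy in place of methyl on an aromatic carbon. Among the compounds with values here, the only measured step, the chloro-to-methyl change, left the number essentially where it was, which suggests that this position is tolerant of a small substituent; no step involving a methoxy or any other oxygen-bearing group has been measured, so the methyl-to-methoxy change has no direct precedent. The expectation for compound 3 is therefore a change of a 1.4-fold higher number from compound 2 to compound 3 (0.14 log units; within the scatter) in this assay, with the number estimated at 150 nM in a range from 60 nM to 400 nM.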

Compound 3, inhibition constant: 3900 nM
The estimate for compound 3 lay 26-fold (1.41 log units) below the measured number; the whole stated range lies below it.
By their numbers in this assay, from the lowest: compounds 1 and 2 (each within the scatter of the next); then compound 3.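

Working from the position on the six-membered aromatic ring of carbon only, meta to a large group, in this assay the methoxy in place of methyl is a large step (a 36-fold higher number from compound 2 to compound 3 (1.55 log units; beyond the scatter)), and the methoxy in place of chloro is larger still in printed size (a 57-fold higher number from compound 1 to compound 3 (1.76 log units; beyond the scatter)). The tolerance suggested by the chloro-to-methyl step therefore does not extend to every small substituent here: chloro and methyl sit within the scatter of each other, while methoxy stands well apart from both. The oxygen of the methoxy is the visible structural difference from methyl, but this is only a correlation across three compounds, and no available measurement accounts for the size of the step.

Still open, as far as these compounds go, is whether the oxygen itself or simply the extra heavy atom tracks with the large step; an ethyl group and a hydroxy group at this position would help separate the two. An amine here, or a methoxy elsewhere on the same ring, would show how far the effect reaches.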